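The source may hold more compounds than are shown below. What is called first, only, known or untested is meant among the compounds shown, and "the series" means these compounds.

Measured so far in an assay on isolated protein for inhibition of protein kinase C theta type (Homo sapiens), read by TR-FRET, with a stated time of 2 h; on this read-out lower numbers stand for stronger inhibition and higher numbers for weaker inhibition:
- compound 1, `N#Cc1cnc(NCc2cnccc2C(F)(F)F)cc1N[C@H]1CC[C@@H](n2cncn2)CC1`: 100 nM
- compound 2, `CC1(C)C[C@H](Nc2nc(NCc3cnccc3C(F)(F)F)ncc2C#N)CC[C@@H]1O`: 6 nM

Compound 2 holds the lowest number of the two in this assay; the nearest, compound 1, sits well above it, a gap beyond the usual scatter, so compound 2 is the more potent of the pair, though with one neighbour only no trend can be read from this.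

Compound 3, `CC1(C)[C@@H](Nc2nc(NCc3cnccc3C(F)(F)F)ncc2C#N)C[C@@H]1O`, keeps the shared core of compound 2 and changes only the ring carried on the amine: 3-hydroxy-2,2-dimethylcyclobutyl in place of 4-hydroxy-3,3-dimethylcyclohexyl on a nitrogen on an aromatic ring. Within the data shown here, no measured pair in the set isolates such a ring contraction, so the size of the step has no precedent here. A moderate loss of potency is the expectation, with the possibility that the number stays within scatter of compound 2. The expected step for this assay, a 3.3-fold higher number from compound 2 to compound 3 (0.52 log units; beyond the scatter), is taken as a worsening. Compound 3 is estimated at 20 nM, in the range 5 nM to 80 nM.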

Compound 3, half-maximal inhibitory concentration: 170 nM
For compound 3 the middle estimate is 8.5-fold (0.93 log units) below the measured one; the measured number lies above the stated range.
By their numbers in this assay, from the lowest: compound 2; then compounds 1 and 3 (each within the scatter of the next).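

In this assay, the group on a nitrogen on an aromatic ring proves sensitive to this change: 3-hydroxy-2,2-dimethylcyclobutyl in place of 4-hydroxy-3,3-dimethylcyclohexyl gives a 28-fold higher number from compound 2 to compound 3 (1.45 log units; beyond the scatter), a large loss of potency. Hydroxy and gem-dimethyl groups are both kept and the counted hydrogen-bond donor and acceptor stay the same, so keeping these features does not preserve potency once the six-membered ring gives way to the four-membered one. Nothing measured here accounts for the loss.

The step bundles ring size with the placement of the hydroxy and dimethyl groups on the ring, and these compounds do not separate the two. A five-membered carbon ring, or an amine in place of the hydroxy group on the six-membered ring, remains an open test of what this position requires.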